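A Halogenated Phenyl Swap on a Shared Chain

This account rests on a few compounds, and the source may have more. Where it says the series, first, only, none or still open, it means among the compounds named here.

In a functional assay on HCT-116 cells (Homo sapiens) for inhibition, read by colorimetric assay, with a stated time of 3 days (a lower number here means a stronger inhibitor, a higher number a weaker inhibitor), compound 1 `O=C(CCCCCCNC(=O)C(O)(O)C(F)(F)F)Nc1ccccc1Br` gives 14500 nM, the highest of the two numbers recorded here. Its nearest neighbour is compound 3 `COc1ccc2nc(NC(=O)CCCCCCNC(=O)C(O)(O)C(F)(F)F)sc2c1`, which gives 7560 nM; the gap between these two lies within the scatter, so no order can be read from it. Compound 2 `O=C(CCCCCCNC(=O)C(O)C(F)(F)F)Nc1nccs1` reaches only the limit of the assay, > 40000 nM. Compound 4 `O=C(CCCCCCNC(=O)C(O)(O)C(F)(F)F)Nc1ccc(F)cc1` is compound 1 with 4-fluorophenyl in place of 2-bromophenyl on an amide-type nitrogen. Among the measured compounds shown here, no measured pair shows what this change does to the number, so there is nothing here that points either up or down. The expectation is therefore a step of no change at the digits printed from compound 1 to compound 4 (within the scatter), none beyond the scatter. Compound 4 is estimated at 14500 nM, in a range from 5000 nM to 40000 nM.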

Compound 4, half-maximal inhibitory concentration: 7570 nM
Compound 4: middle estimate off by 1.9-fold (0.28 log units), on the high side; the measured number falls inside the stated range.
By their numbers in this assay, from the lowest: compounds 3, 4 and 1 (each within the scatter of the next). At a limit, above all of these: compound 2.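

Among the compounds shown here, the first direct reading at this position is a 1.9-fold lower number from compound 1 to compound 4 (0.28 log units; within the scatter) and so, in this assay, 2-bromophenyl and 4-fluorophenyl on the amide-type nitrogen cannot be told apart. The two groups differ in both the halogen and its numbered place on the ring, so this single step cannot separate those two changes. Nothing measured here offers a reason for the result.

As far as these compounds go, whether a halogen on this ring matters at all stays open. A plain phenyl, or a phenyl carrying chlorine or a nitrile, on this nitrogen would help to answer that.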